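Ester to acid on a second core: solubility expectation

A few compounds are considered here, and "the series" means these few. Any claim that something is new, unique, unknown or untested is made for them only; others in the source may bear on it.

Measured so far:
compound 1, `CCOCCCCc1[nH]c2ccc([N+](=O)[O-])cc2c(=O)c1C(=O)OCC`, 5000 nM
compound 2, `CCOCCCCc1[nH]c2ccc([N+](=O)[O-])cc2c(=O)c1C(=O)O`, 50000 nM
compound 3, `CCCCCCCc1[nH]c2ccncc2c(=O)c1C(=O)OCC`, 50000 nM

Of the compounds shown here, three have been measured in a physicochemical assay for solubility, read by HPLC, at pH 7.4; on this read-out higher numbers stand for higher solubility and lower numbers for lower solubility. Compound 1 carries an ethyl ester and gives 5000 nM. Compound 2 differs from it by hydrogen in place of ethyl on an oxygen next to a carbonyl group, and the step is a 10-fold higher number from compound 1 to compound 2 (1.00 log units; beyond the scatter). Compound 3 sits on a different core and gives 50000 nM; it stands level with compound 2 at the digits given, which is within the scatter, and it is a larger number than compound 1. How the core of compound 3 differs from the core of compound 1 is not broken down here.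

Compound 4, `CCCCCCCc1[nH]c2ccncc2c(=O)c1C(=O)O`, has not yet been measured in this assay. It is made from compound 3 by the same change that turned compound 1 into compound 2: hydrogen in place of ethyl on an oxygen next to a carbonyl group, at the same kind of place. Going by the values given here, the only guide to its size is the one earlier step, so the expectation for compound 4 rests on compound 3 at 50000 nM together with the earlier step of a 10-fold higher number from compound 1 to compound 2 (1.00 log units; beyond the scatter). Among the compounds with values here, a step of about the same size is expected again, a 6.0-fold higher number from compound 3 to compound 4 (0.78 log units; beyond the scatter), with wide room on either side since only one example exists and since the core is different. On that footing compound 4 is estimated at 300000 nM, expected to fall between 80000 nM and 1500000 nM.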

Compound 4, solubility: 50000 nM
For compound 4 the middle estimate is 6.0-fold (0.78 log units) above the measured one, outside the stated range (below it).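

In this assay the replacement of ethyl by hydrogen on an oxygen next to a carbonyl group gives no change at the digits printed from compound 3 to compound 4 (within the scatter) while the same replacement on the core of compound 1 gave a 10-fold higher number from compound 1 to compound 2 (1.00 log units; beyond the scatter) as its result. This shows that the size of a step read on one core did not carry over to the other in this series, so the earlier pair alone is a poor guide to what the same swap will do elsewhere, and one pair beyond the scatter and one within it make no rule in either direction. It does not show why the two pairs part ways, nor which difference between the two cores matters, and nothing measured here bears on the reason.

Compound 1 and compound 3 differ in more than one place, so the chain and the ring part of the core cannot be told apart as the source of the contrast, and a pair that differs only in the chain or only in the ring would be needed to separate them. Also open, as far as these compounds go, is how other replacements for the ethyl ester, such as a methyl ester or a primary amide, or an amine on the chain, would read on each core.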